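The source may report more compounds than this note shows. Statements on the series, on what has been measured and on what is new or still open speak of the compounds shown alone.

Compound 1 `COC(=O)c1ccc(-c2ccc(CN3CCCN(C)CC3)cc2)cc1` gives 2400 nM in an assay on isolated protein for binding affinity to choline kinase alpha (Homo sapiens), read by surface plasmon resonance; a lower number here means tighter binding, a higher number weaker binding.
Compound 2 `CN1CCCN(Cc2ccc(-c3ccc(CN4CCCN(C)CC4)cc3)cc2)CC1` gives 382 nM in this assay.

Within the data shown here, of these two numbers, compound 2 holds the lower one, and the single measured step, a 6.3-fold lower number from compound 1 to compound 2 (0.80 log units; beyond the scatter), is modest. Compound 3 `CN1CCCN(Cc2ccc(-c3ccc(CN4CCCN(C)CC4)c(Cl)c3)cc2)CC1` differs from compound 2 by chloro in place of hydrogen on an aromatic carbon. Among the measured compounds shown here, no measured step involves a chloro entering an aromatic ring, so the step from compound 1 to compound 2 offers no guide here, and the expectation is that the step of a 1.0-fold lower number from compound 2 to compound 3 (0.00 log units; within the scatter) stays within the scatter. Compound 3 is therefore expected to give about 380 nM in this assay, within a range from 150 nM to 1000 nM.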

Compound 3, dissociation constant: 88 nM
For compound 3 the middle estimate is 4.3-fold (0.64 log units) above the measured one; the whole stated range lies above it.
By their numbers in this assay, from the lowest: compound 3; then compound 2; then compound 1.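

Chloro in place of hydrogen on an aromatic carbon, ortho to a (4-methyl-1,4-diazepan-1-yl)methyl group, gives tighter binding in this assay (a 4.3-fold lower number from compound 2 to compound 3 (0.64 log units; beyond the scatter)). This shows that a single added atom on this ring can shift the number, whereas the earlier step exchanged a whole group. Nothing measured here explains this shift.

The compounds shown leave open whether fluoro, bromo or methyl on this same carbon would shift the number likewise. They also leave open whether chloro would do so on another carbon of this ring.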